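Bromo at a Second Position on the Naphthyloxy Group

The compounds below may be only part of what the source reports. "The series", "measured", "known", "first", "only" and "open" are said of these compounds alone.

Of the compounds shown here, three sharing one core have been tested in an ADME assay on MT4 cells (Homo sapiens) for cytotoxicity, read by MTT assay, with a stated time of 4 days; a lower number here means that less compound is tolerated, a higher number that more compound is tolerated. Compound 1 `N#Cc1ccc(Nc2nc(N)nc(Oc3ccc4ccccc4c3)n2)cc1` gives 42200 nM. Compound 2 `N#Cc1ccc(Nc2nc(N)nc(Oc3ccc4ccccc4c3Br)n2)cc1` carries a bromo on the same ring system and gives 133000 nM. Compound 3 `N#Cc1ccc(Nc2nc(N)nc(Oc3ccc4ccccc4c3Cl)n2)cc1` gives 32200 nM. Compound 1 thus stands second highest of the three; compound 3 lies closest, within the usual scatter, while compound 2 lies furthest, as shown by a 3.2-fold higher number from compound 1 to compound 2 (0.50 log units; beyond the scatter) and a 1.3-fold lower number from compound 1 to compound 3 (0.12 log units; within the scatter). Swapping the halogens, a 4.1-fold lower number from compound 2 to compound 3 (0.62 log units; beyond the scatter), gives the largest step seen so far.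

Compound 4 `N#Cc1ccc(Nc2nc(N)nc(Oc3ccc4cc(Br)ccc4c3)n2)cc1` differs from compound 1 by bromo in place of hydrogen on an aromatic carbon. For the measured compounds named here, the one step that bears on it is the bromo addition in compound 2, a 3.2-fold higher number from compound 1 to compound 2 (0.50 log units; beyond the scatter), a modest rise. A bromo placed on another carbon of the same ring system may not behave the same way, so a rise of similar size or none beyond the scatter is expected. Compound 4 is therefore estimated at 65000 nM, within 25000 nM to 170000 nM, meaning a 1.5-fold higher number from compound 1 to compound 4 (0.19 log units; within the scatter).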

Compound 4, half-maximal cytotoxic concentration: 243000 nM
The estimate for compound 4 lay 3.7-fold (0.57 log units) below the measured number, outside the stated range (above it).
By their numbers in this assay, from the lowest: compounds 3 and 1 (each within the scatter of the next); then compounds 2 and 4 (each within the scatter of the next).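

In this assay, bromo in place of hydrogen on this aromatic carbon, meta to a fused ring and para to a fused ring, gives a 5.8-fold higher number from compound 1 to compound 4 (0.76 log units; beyond the scatter). The rise seen with compound 2 is therefore not a single case: bromo on two different carbons of the ring system gives a higher number than hydrogen, and compound 2 and compound 4 stand within the scatter of each other. No measurement shown here explains this rise.

Going by these compounds, it remains open whether chloro on this carbon would stay within the scatter of compound 1, as the chloro of compound 3 does on its own carbon. Also open, on these data alone, is what an amine or a carboxylic acid would give here in place of bromo.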